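The source may report more compounds than this note shows. Statements on the series, on what has been measured and on what is new or still open speak of the compounds shown alone.

Working notes on the series. Compound 1 `O/N=C(/Nc1cccc(C(F)(F)F)c1)c1ccc2occc2c1` gives 1900 nM in an assay on tissue (HeLa cells) for inhibition of Indoleamine 2,3-dioxygenase 1 (Homo sapiens), read by spectrophotometry; on this read-out lower numbers stand for stronger inhibition and higher numbers for weaker inhibition. Compound 2 `O/N=C(/Nc1ccc(F)c(C(F)(F)F)c1)c1ccc2occc2c1` differs from compound 1 by fluoro in place of hydrogen on an aromatic carbon. In this assay compound 2 gives 2200 nM. The step is a 1.2-fold higher number from compound 1 to compound 2 (0.06 log units; within the scatter), so the two numbers cannot be told apart.

Compound 3 `O/N=C(/NCc1cccc(Cl)c1)c1ccc2occc2c1` carries a different core; how the core of compound 3 differs from the core of compound 1 is not broken down here. In this assay compound 3 gives 5800 nM, a higher number than either compound 2 or compound 1 by margins that lie beyond the scatter.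

Compound 4 `O/N=C(/NCc1ccc(F)c(Cl)c1)c1ccc2occc2c1` has not yet been measured. It differs from compound 3 by fluoro in place of hydrogen on an aromatic carbon. Among the measured compounds shown here, this is the same kind of change as the one that separates compound 2 from compound 1, not the same change: in the earlier pair the entering fluoro stands ortho to a trifluoromethyl group, here it stands ortho to a chloro group, in both cases para to a large group. For the measured compounds named here, the only measured instance of this kind of change is a 1.2-fold higher number from compound 1 to compound 2 (0.06 log units; within the scatter), and it stays within the scatter. On that single precedent the step is expected to be small as well, about a 1.1-fold higher number from compound 3 to compound 4 (0.05 log units; within the scatter), with the caution that one pair on a different core is thin ground. Compound 4 is therefore estimated at 6500 nM in this assay, with a plausible range from 3000 nM to 14000 nM.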

Compound 4, half-maximal inhibitory concentration: 17600 nM
Compound 4: the middle estimate sits 2.7-fold (0.43 log units) below what was measured; the whole stated range lies below it.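

In this assay, fluoro in place of hydrogen on an aromatic carbon gives a 3.0-fold higher number from compound 3 to compound 4 (0.48 log units; beyond the scatter) and so lies beyond the scatter on its own, whereas the earlier instance of this change, on the core of compound 1, stays within it. Set side by side, however, the two steps cannot be told apart: the same change on two cores in this assay, a 1.2-fold higher number (0.06 log units; within the scatter) from compound 1 to compound 2 and a 3.0-fold higher number (0.48 log units; beyond the scatter) from compound 3 to compound 4, 2.6-fold (0.42 log units) apart, within the scatter of two such steps. Among the compounds shown here, the data therefore do not show that this change behaves differently on the two cores, nor do they show that it carries over with a fixed size, since only two pairs are available and these differ both in the core and in the group already on the ring, trifluoromethyl in one pair and chloro in the other.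

From the compounds shown here alone, whether a further pair would settle the size of the step, on either core, stays open, and so does whether the core or the group already on the ring matters more for it. Also open is how methoxy, a nitrile or an amine entering at the same place would read in this assay on the core of compound 3, as only fluoro is shown there.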